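Adding Benzyloxy to Compound 1

This account rests on a few compounds, and the source may have more. Where it says the series, first, only, none or still open, it means among the compounds named here.

Going by the values given here, in a functional assay on B16-F10 cells (Mus musculus) for antiproliferative activity, read by MTT assay, with a stated time of 48 h (on this read-out lower numbers stand for stronger inhibition and higher numbers for weaker inhibition), compound 1 `CC(=O)N1N=C(c2ccc3ccccc3c2)OC1c1ccccc1` gives 2.57 ug/mL, the lowest of the three numbers measured so far. Compound 2 `CC(=O)N1N=C(c2ccc3ccccc3c2)OC1c1ccccc1[N+](=O)[O-]` gives 9.01 ug/mL and compound 3 `CC(=O)N1N=C(c2ccc3ccccc3c2)OC1c1ccsc1` gives 8.56 ug/mL, two values within the scatter of each other. Compound 4 `CC(=O)N1N=C(c2ccc3ccccc3c2)OC1c1ccc(OCc2ccccc2)cc1` has not yet been measured. It carries benzyloxy in place of hydrogen on an aromatic carbon, para to a large group (benzyloxy in place of hydrogen on an aromatic carbon). The closest measured change is nitro in place of hydrogen on an aromatic carbon, which gave a 3.5-fold higher number from compound 1 to compound 2 (0.54 log units; beyond the scatter). Thiophen-3-yl in place of phenyl, a change at another place, gave a 3.3-fold higher number from compound 1 to compound 3 (0.52 log units; beyond the scatter). Among the compounds with values here, both changes were modest and both moved the number upward, but no measured compound carries benzyloxy, so the size of the new step remains uncertain. A modest step toward weaker inhibition is therefore expected in this assay. The estimated step is a 2.3-fold higher number from compound 1 to compound 4 (0.37 log units; beyond the scatter). For compound 4 the expected value is 6 ug/mL, with an estimated range from 2.5 ug/mL to 14 ug/mL.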

Compound 4, half-maximal inhibitory concentration: 8.08 ug/mL
Estimate against measurement, compound 4: 1.3-fold (0.13 log units) below; the range from low to high includes it.
By their numbers in this assay, from the lowest: compound 1; then compounds 4, 3 and 2 (each within the scatter of the next).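

In this assay, benzyloxy on an aromatic carbon, para to a large group, brings a 3.1-fold higher number from compound 1 to compound 4 (0.50 log units; beyond the scatter) and so does not preserve the low number of compound 1. With a 3.5-fold higher number from compound 1 to compound 2 (0.54 log units; beyond the scatter) as the only other substitution on that phenyl ring, both substituents shown raise the number by a modest step, although benzyloxy brings its own six-membered aromatic ring of carbon only. No measurement shown here explains this rise.

The compounds shown leave open whether any group at this place would keep the number near that of compound 1, or whether the rise belongs to benzyloxy and nitro alone. A methoxy group, a hydroxyl group or an amine at this same carbon would begin to answer that.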